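Swapping the halogen-bearing ring on the cinnamide chain

This account rests on a few compounds, and the source may have more. Where it says the series, first, only, none or still open, it means among the compounds named here.

Measured so far:
compound 1 `CCCc1cc(N)c2cc(NC(=O)/C=C/c3ccc(F)cc3)ccc2n1`: 130 nM
compound 2 `CCCCc1ccc(/C=C/C(=O)Nc2ccc3nc(CCC)cc(N)c3c2)cc1`: 45 nM

Both compounds were tested in an assay on isolated protein for displacement of a labelled ligand from melanin-concentrating hormone receptor 1 (Homo sapiens); on this read-out lower numbers stand for stronger inhibition and higher numbers for weaker inhibition. Going by the values given here, compound 1 gives the higher of the two numbers; the only measured step, a 2.9-fold lower number from compound 1 to compound 2 (0.46 log units; beyond the scatter), changes a different part of the molecule. Compound 3 `CCCc1cc(N)c2cc(NC(=O)/C=C/c3ccccc3Cl)ccc2n1` differs from compound 1 by 2-chlorophenyl in place of 4-fluorophenyl on a double-bonded chain carbon bound to a double-bonded chain carbon. Among the compounds with values here, no measured step bears on this change, so nothing beyond the scatter is expected; the estimated step is a 1.2-fold lower number from compound 1 to compound 3 (0.07 log units; within the scatter). Compound 3 is therefore expected to give about 110 nM, within 40 nM to 350 nM.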

Compound 3, half-maximal inhibitory concentration: 120 nM
For compound 3 the middle estimate is 1.1-fold (0.04 log units) below the measured one; the measured number falls inside the stated range.
By their numbers in this assay, from the lowest: compound 2; then compounds 3 and 1 (each within the scatter of the next).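

Within this assay, 2-chlorophenyl in place of 4-fluorophenyl gives a 1.1-fold lower number from compound 1 to compound 3 (0.03 log units; within the scatter), so this position accepts a change of both the halogen and where it sits on the ring without a readable shift in the number. The two changes come together here. Neither can be judged alone. No measurement shown here explains this result. Still open, from the compounds shown here alone, is whether a hexyl chain in place of the butyl of compound 2, or an amine or carboxylic acid on this ring, would move the number beyond the scatter.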